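A few compounds are considered here, and "the series" means these few. Any claim that something is new, unique, unknown or untested is made for them only; others in the source may bear on it.

Three compounds have been measured in a functional assay with Mus musculus as the target; a lower number here means that less compound is needed, a higher number that more compound is needed for the effect:

Compound 1 `CCCn1c(=O)n(C2OC(COP(=O)(O)O)[C@@H](O)[C@H]2O)c2nc(N)nc(O)c21` — 82 uM
Compound 2 `COc1ccc(Cn2c(=O)n(C3OC(CO)[C@@H](O)[C@H]3O)c3nc(N)nc(O)c32)cc1` — 2 uM
Compound 3 `C=CCn1c(=O)n(C2C=CC(CO)O2)c2nc(N)nc(O)c21` — 30 uM

In this assay compound 2 gives the lowest number of the three, and its separation from compound 3 and from compound 1 lies beyond the usual scatter, so it stands apart on the present data. Compound 4 `Cn1c(=O)n(C2OC(CO)[C@@H](O)[C@H]2O)c2nc(N)nc(O)c21` differs from compound 2 by a single change: hydrogen in place of 4-methoxyphenyl on a saturated chain carbon bound to an aromatic nitrogen. Within the data shown here, no directly comparable pair has been measured. Still, compound 1 and compound 3, which also lack the 4-methoxyphenyl, give higher numbers than compound 2, though each differs from compound 2 in other places too. A rise beyond the scatter is therefore expected, with the step estimated at a 10-fold higher number from compound 2 to compound 4 (1.00 log units; beyond the scatter). Compound 4 is expected to give 20 uM in this assay, within a range from 5 uM to 80 uM.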

Compound 4, concentration for half-maximal effect: 120 uM
The estimate for compound 4 lay 6.0-fold (0.78 log units) below the measured number, outside the stated range (above it).
By their numbers in this assay, from the lowest: compound 2; then compound 3; then compounds 1 and 4 (each within the scatter of the next).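

In this assay, replacing 4-methoxyphenyl with hydrogen on a saturated chain carbon bound to an aromatic nitrogen gives a 60-fold higher number from compound 2 to compound 4 (1.78 log units; beyond the scatter), a large step. Among these compounds, the same difference reads as 4-methoxybenzyl to methyl, and it is the first change confined to this one place, since the earlier compounds differed from each other in several places. Nothing available accounts for the size of this step.

The compounds shown leave open whether the methoxy group contributes or the aromatic ring alone is enough. An unsubstituted benzyl, a longer chain or an amine at this place would help to separate these possibilities.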